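Chain Extension on Two Uracil-Derived Carbamate Cores

The source may report more compounds than this note shows. Statements on the series, on what has been measured and on what is new or still open speak of the compounds shown alone.

Compound 1 `CCCCCCNC(=O)n1cc(C)c(=O)[nH]c1=O` and compound 2 `CCCCCCNC(=O)n1cc(CC)c(=O)[nH]c1=O` share one core; in an assay on HEK293 cells for inhibition of acid ceramidase (Rattus norvegicus), read by LC-MS, with a stated time of 30 min (a higher number here means a weaker inhibitor, a lower number a stronger inhibitor), compound 1 gives 1460 nM and compound 2 gives 733 nM, so a 2.0-fold lower number from compound 1 to compound 2 (0.30 log units; within the scatter). That change is methyl in place of hydrogen on a saturated chain carbon bound to an aromatic carbon. Compound 3 `CCCCCCNC(=O)n1cc(F)c(=O)n(C)c1=O` stands on a second core; the difference between the two cores is not broken down here. In this assay compound 3 gives 13 nM, the lowest number of the three. Compound 4 `CCCCCCNC(=O)n1cc(F)c(=O)n(CC)c1=O` differs from compound 3 by methyl in place of hydrogen on a saturated chain carbon bound to an aromatic nitrogen. This is the same kind of change as from compound 1 to compound 2, but here the saturated chain carbon is bound to an aromatic nitrogen rather than to an aromatic carbon. Since the earlier step stayed within the scatter, the step of a 1.2-fold higher number from compound 3 to compound 4 (0.06 log units; within the scatter) is expected to be small as well. Compound 4 is therefore estimated at 15 nM, between 5 nM and 50 nM.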

Compound 4, half-maximal inhibitory concentration: 18 nM
Compound 4: the middle estimate sits 1.2-fold (0.08 log units) below what was measured; the measured number falls inside the stated range.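

In this assay, the methyl added to the second core gives a 1.4-fold higher number from compound 3 to compound 4 (0.14 log units; within the scatter), and the two steps for this change do not fully agree: the same change on two cores in this assay, a 2.0-fold lower number (0.30 log units; within the scatter) from compound 1 to compound 2 and a 1.4-fold higher number (0.14 log units; within the scatter) from compound 3 to compound 4, 2.8-fold (0.44 log units) apart, beyond the scatter of two such steps Each step on its own stays within the scatter, yet the gap between them does not, and this argues against carrying the step from one core to the other as a fixed number. The result does not separate the effect of the core from that of the place, as the methyl sits on a saturated chain carbon bound to an aromatic carbon in one step and to an aromatic nitrogen in the other.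

The compounds shown leave open how a longer chain, such as propyl, would read on either core in this assay. They also leave open how a cyclopropyl ring would read in place of the ethyl.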